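The source may hold more compounds than are shown below. What is called first, only, known or untested is meant among the compounds shown, and "the series" means these compounds.

The two measured compounds share one core and differ in two places at once. Compound 1 `COc1cc(Nc2nc3ccccc3nc2S(=O)(=O)c2ccc(C)cc2)cc(OC)c1` carries a 3,5-dimethoxyphenyl on the nitrogen on the aromatic ring together with a methylphenyl sulfone; in a functional assay on A549 cells (Homo sapiens) for cytotoxicity, read by MTT assay, with a stated time of 72 h (on this read-out lower numbers stand for stronger inhibition and higher numbers for weaker inhibition), compound 1 gives 8060 nM. Compound 2 `O=S(=O)(c1ccc(Br)cc1)c1nc2ccccc2nc1Nc1ccccc1` carries an unsubstituted phenyl on that nitrogen together with a bromophenyl sulfone; in this assay compound 2 gives 10800 nM. Compound 2 stands at the larger of the two numbers, but its gap to compound 1 lies within the scatter, so the two cannot be told apart.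

Compound 3 `COc1cc(Nc2nc3ccccc3nc2S(=O)(=O)c2ccc(Br)cc2)cc(OC)c1` keeps the bromophenyl sulfone of compound 2 and takes the group that compound 1 carries on the nitrogen: 3,5-dimethoxyphenyl in place of phenyl on a nitrogen on an aromatic ring. For the measured compounds named here, no measured pair isolates this change, so its size is not known from the data. Compound 1 holds the same group beside a different sulfone and gives a similar number, which gives no reason to expect a large effect. The expected step is small, at most a modest drop: a 1.4-fold lower number from compound 2 to compound 3 (0.13 log units; within the scatter). Compound 3 is therefore expected at 8000 nM in this assay, with a range from 3000 nM to 20000 nM.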

Compound 3, half-maximal inhibitory concentration: 15900 nM
Estimate against measurement, compound 3: 2.0-fold (0.30 log units) below; the measured number falls inside the stated range.
By their numbers in this assay, from the lowest: compounds 1, 2 and 3 (each within the scatter of the next).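

In this assay, the pair that isolates the group on the nitrogen gives a 1.5-fold higher number from compound 2 to compound 3 (0.17 log units; within the scatter): with the bromophenyl sulfone held constant, 3,5-dimethoxyphenyl and phenyl on a nitrogen on an aromatic ring cannot be told apart. The pair that isolates the sulfone substituent, with 3,5-dimethoxyphenyl held constant, gives a 2.0-fold higher number from compound 1 to compound 3 (0.30 log units; within the scatter), so bromo and methyl on an aromatic carbon cannot be told apart either. Neither single change moves the number beyond the usual scatter, and no supporting measurement is available to bear on these results.

All three compounds carry an aromatic ring on that nitrogen, so the shown data leave open whether a saturated group there, such as morpholine or a short alkyl chain carrying an amine, would give a step beyond the scatter. Going by these compounds, it also remains open whether a carboxylic acid or a nitrile in place of the bromo or methyl on that aromatic carbon would separate from these compounds in this assay.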